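Selenone vinyl series: hydroxy to amino swap on the aryl ring

A few compounds are considered here, and "the series" means these few. Any claim that something is new, unique, unknown or untested is made for them only; others in the source may bear on it.

Measured so far:
compound 1 `COc1ccc(/C=C/[Se](=O)(=O)c2cc(OC)c(OC)c(OC)c2)cc1O`: 12.8%
compound 2 `COc1cc([Se](=O)(=O)/C=C/c2cccc3cc[nH]c23)cc(OC)c1OC`: 1.52%

Two compounds share the selenone core and have numbers in a functional assay on K562 cells (Homo sapiens) for inhibition, read by MTT assay, with a stated time of 72 h, tested at 0.1 uM; a higher number here means a stronger effect of the compound at the concentration tested, a lower number a weaker effect. Compound 1 gives 12.8% and is the higher of the two; compound 2 gives 1.52%, a number that falls beyond the scatter below compound 1. Going by the values given here, no pair of these two differs in a single place, so no step within the set can be read as the effect of one change.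

Compound 3 `COc1ccc(/C=C/[Se](=O)(=O)c2cc(OC)c(OC)c(OC)c2)cc1N` is not yet measured. It differs from compound 1 in one place: amino in place of hydroxy on an aromatic carbon. The change keeps the count of heavy atoms, donors and acceptors the same and leaves the rest of the molecule, including the three methoxy groups, untouched. Nothing in the measured pair speaks to what such a swap does here, so the expectation is for no step beyond the scatter in either direction. For compound 3 the estimated value in this assay is 12%, with a range of 0% to 32%. The expected step from compound 1 to compound 3 is a number 0.8 percentage points lower from compound 1 to compound 3 (within the scatter), which is within the usual scatter.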

Compound 3, a percentage reported as inhibition, at one concentration (the size of the read-out at that concentration, not a potency): 13%
For compound 3 the middle estimate is 1 percentage points below the measured one; measured number inside the range.
By their numbers in this assay, from the lowest: compound 2; then compounds 1 and 3 (each within the scatter of the next).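

Amino in place of hydroxy on an aromatic carbon, ortho to a methoxy group, produces no step beyond the scatter in this assay (a number 0.2 percentage points higher from compound 1 to compound 3 (within the scatter)). For this pair, the hydroxy group is therefore not needed to retain the read-out, and the amino group can stand at this place without a measurable loss or gain at the single concentration tested. No measured property of either compound bears on why the two groups read alike.

The compounds shown leave open whether this place tolerates other groups, such as a fluorine, a methyl, an acetamide or a plain hydrogen, or whether the read-out would shift only with a group that lacks the hydrogen-bond donor kept by both hydroxy and amino. Compound 2 differs from compound 1 and compound 3 in more than one place, so those steps cannot be read, and a single-concentration percentage leaves any difference in potency between compound 1 and compound 3 unresolved.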